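The source may hold more compounds than are shown below. What is called first, only, known or untested is meant among the compounds shown, and "the series" means these compounds.

Working notes on the series. The shared core of compound 1 `CCOC(=O)C1=C(Nc2ccccc2)S/C(=C\c2ccc(O)c(O)c2)C1=O` carries differing groups on the double-bonded chain carbon bound to a double-bonded ring carbon. In a functional assay on JAR cells (Homo sapiens) for inhibition, read by MTT assay, with a stated time of 72 h, tested at 10 uM (a lower number here means less inhibition, a higher number more inhibition at the concentration tested (going by the name of the read-out)), compound 1 gives 48.7%. Compound 3 `CCOC(=O)C1=C(Nc2ccccc2)S/C(=C\c2cc(OC)c(O)c(OC)c2)C1=O` gives 57.5% in this assay, within the scatter of compound 1. Compound 2 `CCOC(=O)C1=C(Nc2ccccc2)S/C(=C\c2ccccc2C(F)(F)F)C1=O` gives 29% in this assay, a lower number than compound 1 by more than the scatter, so compound 1 stands second highest of the three and only its gap to compound 2 is beyond the scatter. The unmeasured compound 4 `CCOC(=O)C1=C(Nc2ccccc2)S/C(=C\c2cc[nH]c2)C1=O` differs from compound 1 in one place: 1H-pyrrol-3-yl in place of 3,4-dihydroxyphenyl on a double-bonded chain carbon bound to a double-bonded ring carbon. The step from compound 1 to compound 4 in this assay is expected to be a decrease near the edge of the scatter, a number 12.7 percentage points lower from compound 1 to compound 4 (beyond the scatter). Compound 4 is expected to give 36% in this assay, between 18% and 54%.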

Compound 4, a percentage reported as inhibition, at one concentration (the size of the read-out at that concentration, not a potency): 19.5%
Estimate against measurement, compound 4: 16.5 percentage points above; low and high end bracket the measured number.
By their numbers in this assay, from the lowest: compounds 4 and 2 (each within the scatter of the next); then compounds 1 and 3 (each within the scatter of the next).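

In this assay, the first step read at this position, 1H-pyrrol-3-yl in place of 3,4-dihydroxyphenyl on a double-bonded chain carbon bound to a double-bonded ring carbon, gives a number 29.2 percentage points lower from compound 1 to compound 4 (beyond the scatter). Compound 4 at 19.5% stays within the scatter of compound 2 at 29%, so this five-membered ring does not set itself apart from that compound. No measurement bears on why the number falls with this change. Still open, as far as these compounds go, is whether the step follows the ring or its hydroxyl groups; a plain phenyl or a furan ring at this place would separate the two.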